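The compounds below may be only part of what the source reports. "The series", "measured", "known", "first", "only" and "open" are said of these compounds alone.

Measured compounds:
Compound 1 `COc1cc(/C=C/C(=O)/C=C/c2cccc3ccccc23)ccc1OCc1cn(CCCOc2cc(=O)oc3ccccc23)nn1` — 8%
Compound 2 `COc1cc(/C=C/C(=O)/C=C/c2cccc3ccccc23)ccc1OCc1cn(CCCCOc2cc(=O)oc3ccccc23)nn1` — "not active" (no number reported)
Compound 3 `COc1cc(/C=C/C(=O)/C=C/c2cc(OC)c(OC)c(OC)c2)ccc1OCc1cn(CCCCOc2cc(=O)oc3ccccc23)nn1` — 5%

In a functional assay on PC-3 cells (Homo sapiens) for inhibition, read by sulforhodamine B assay, with a stated time of 48 h, tested at 50 uM (a higher number here means more inhibition of growth at the concentration tested, a lower number less inhibition of growth), compound 1 gives 8%, the higher of the two numbers reported. Compound 3 gives 5%, which lies within the scatter of the value of compound 1, so the two cannot be ordered. Compound 2 is reported as "not active" (no number reported) without a number. All three compounds share the same core, and none of them inhibits growth to any marked degree at the concentration tested.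

Compound 4 `COc1ccc(/C=C/C(=O)/C=C/c2ccc(OCc3cn(CCCOc4cc(=O)oc5ccccc45)nn3)c(OC)c2)cc1` has not yet been measured. It differs from compound 1 in one place: 4-methoxyphenyl in place of naphthalen-1-yl on a double-bonded chain carbon bound to a double-bonded chain carbon. For the measured compounds named here, no step between two measured compounds isolates this change, so there is no measured guide to its effect. Given that compound 1 and compound 3 both give small numbers in this assay, compound 4 is expected to remain low as well, with a step of a number 2 percentage points lower from compound 1 to compound 4 (within the scatter) that lies within the scatter. The estimate for compound 4 is 6%, between 0% and 20%.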

Compound 4, percent growth inhibition at one concentration: "not active" (no number reported)
Compound 4 has no reported number here; no gap can be computed for the estimate.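

No new step can be read from compound 4, since it, like compound 2, carries no number in this assay. The compounds shown leave open whether any change to the shared core gives marked inhibition of growth. Nothing measured here offers an explanation for this result.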